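Series notes: from compound 2 toward compound 4

This account rests on a few compounds, and the source may have more. Where it says the series, first, only, none or still open, it means among the compounds named here.

Three members of the series have been run in an assay on HL-60 cells for agonist activity at N-formyl peptide receptor 3 (Homo sapiens), read by calcium flux; a lower number here means that less compound is needed, a higher number that more compound is needed for the effect. Compound 1 `COc1cccc(Cc2cc(C3CCCCC3)nn(CC(=O)Nc3ccc(Br)cc3)c2=O)c1` returns only a limit there, > 50000 nM. Compound 2 `Cc1cc(Cc2cccc(F)c2)c(=O)n(CC(=O)Nc2ccc(Br)cc2)n1` likewise sits at a limit, > 50000 nM. Compound 3 `COc1ccc(Nc2c(C(C)=O)c(C)nn(CC(=O)Nc3ccc(Br)cc3)c2=O)cc1` also gives a limit, > 50000 nM. On the numbers shown, compound 2 therefore stands nowhere apart from the others: all three rest at the same point, namely (the limit of > 50000 nM in this assay, at which 3 of the 3 values shown sit), and no measured step between any pair of them exists, so nothing can yet be said about how a structural change moves the read-out in this series.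

Compound 4 `COc1ccc(-c2cc(C)nn(CC(=O)Nc3ccc(Br)cc3)c2=O)cc1` is the next candidate. Relative to compound 2 it carries 4-methoxyphenyl in place of 3-fluorobenzyl on an aromatic carbon. Among the measured compounds shown here, because compound 2 is known only as > 50000 nM, no numerical step can be taken from it. For the measured compounds named here, with every value so far at a limit, the expectation for this assay is no step beyond the scatter, and most likely another limit rather than a number. Compound 4 is accordingly expected to give about 50000 nM, with a range from 15000 nM to 150000 nM. The step this estimate implies, a number no higher from compound 2 to compound 4 (the limit leaves the size open), is expected to carry no meaning beyond the scatter.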

Compound 4, half-maximal effective concentration: > 50000 nM
Compound 4: only a limit was reported (the forecaster's own chance of this, stated with the estimate: 85%); the middle value lies on the limit itself.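

Compound 4 returns > 50000 nM as a limit and not a number. Compound 2 is also known only as a limit, so no step can be read between compound 2 and compound 4. The compounds shown leave open whether any change on the shared core gives a measurable number in this assay: the limit of > 50000 nM in this assay, at which 4 of the 4 values shown sit.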